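The source may report more compounds than this note shows. Statements on the series, on what has been measured and on what is new or still open speak of the compounds shown alone.

The study concerns binding to a kinase variant, measured in an assay on isolated protein for binding affinity to Leucine-rich repeat serine/threonine-protein kinase 2 variant G2019S (Homo sapiens), read by TR-FRET and LanthaScreen, with a stated time of 2 h; a higher number here means a weaker inhibitor, a lower number a stronger inhibitor. Of the compounds shown here, three have been measured so far. Compound 1 `C[C@@H]1CCCN1c1c(C#N)c2c(N)nc(Nc3ccn(C)n3)cc2n1C` gives 13 nM in this assay, and compound 2 `Cc1nn(C)cc1Nc1nc(N)c2c(C#N)c(N3CCC[C@H]3C)n(C)c2n1` gives 2 nM in this assay. Compound 3 `C[C@@H]1CCCN1c1c(C(N)=O)c2c(N)ncnc2n1C`, whose structure stands beside it, gives 154 nM in this assay. Among the three, compound 3 stands highest: its nearest neighbour is compound 1, and the gap between the two lies beyond the usual scatter of repeated measurements, while compound 2 lies furthest from it, again well beyond the scatter.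

The step to be followed leads from compound 3 to compound 4 `C[C@@H]1CCCN1c1cc2c(N)ncnc2n1C`, which has not yet been measured in this assay. The change is hydrogen in place of carbamoyl on an aromatic carbon. Among the measured compounds shown here, no measured pair shows this change on its own, so its effect has to be judged from the structures alone. The carbamoyl of compound 3 carries one hydrogen-bond donor and one hydrogen-bond acceptor, and with only a hydrogen in its place compound 4 is expected to bind less tightly. The step of a 3.9-fold higher number from compound 3 to compound 4 (0.59 log units; beyond the scatter) is expected to be larger than the scatter, toward a weaker inhibitor. Compound 4 is therefore estimated at 600 nM in this assay, with a range from 200 nM to 3000 nM.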

Compound 4, inhibition constant: 439 nM
Compound 4: middle estimate off by 1.4-fold (0.14 log units), on the high side, and the stated range covers the measured number.
By their numbers in this assay, from the lowest: compound 2; then compound 1; then compound 3; then compound 4.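

In this assay, among the compounds shown here, the change of hydrogen in place of carbamoyl on an aromatic carbon gives a 2.9-fold higher number from compound 3 to compound 4 (0.45 log units; beyond the scatter) and so supplies the first step here that isolates a single place, the carbon of the five-membered aromatic ring next to the ring atom that bears a 2-methylpyrrolidin-1-yl group. The step lies beyond the scatter, which shows that the carbamoyl counts at this carbon, but it is modest, and compound 4, with only hydrogen there, still gives 439 nM as a measurable inhibitor, so binding does not depend on the carbamoyl. No measurement at hand explains the size of this step.

The compounds shown leave open whether a carboxylic acid or an aminomethyl group on this carbon would give a lower or a higher number than the carbamoyl does. They also leave open whether a step of this size would hold on the cores of compound 1 and compound 2, which carry a nitrile on this carbon but differ from compound 3 in other places as well.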